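Ethyl to hydrogen on the exocyclic amide of a proline-nitrile series

The source may hold more compounds than are shown below. What is called first, only, known or untested is meant among the compounds shown, and "the series" means these compounds.

The series shares a pyrrolidine-nitrile amide core with an exocyclic carboxamide of varying substitution. Compound 1 `N#C[C@@H]1CCCN1C(=O)[C@@H]1C[C@H](C(=O)N2CCCCCCC2)CN1` carries a cyclic amine on that carboxamide, and in an assay on the whole organism (plasma, strain Sprague-Dawley) for inhibition of Dipeptidyl peptidase 4 (Rattus norvegicus), with a stated time of 10 h, at a dose of 1 mg/kg by the oral route (on this read-out higher numbers stand for more inhibition at the one dose given (going by the name of the read-out) and lower numbers for less inhibition), compound 1 stands at "not determined" (no result reported). Compound 2 `CCN(CC)C(=O)[C@@H]1CN[C@H](C(=O)N2CCC[C@H]2C#N)C1` carries a diethyl amide, and in this assay compound 2 stands at "not determined" (no result reported). Among the compounds with values here, compound 3 `CCNC(=O)[C@@H]1CN[C@H](C(=O)N2CCC[C@H]2C#N)C1` is the ethyl amide, and in this assay compound 3 gives 19%; this is the only number in hand, so compound 3 cannot be placed against any other member by measurement.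

Compound 4 `N#C[C@@H]1CCCN1C(=O)[C@@H]1C[C@H](C(N)=O)CN1` differs from compound 3 in one place: hydrogen in place of ethyl on an amide-type nitrogen. Within the data shown here, no measured pair shows what this kind of change does in this assay. With a single number as the only anchor, the step is expected to stay within the usual scatter, if anything slightly downward, and is estimated as a number 4 percentage points lower from compound 3 to compound 4 (within the scatter). Compound 4 is therefore expected to give 15% in this assay, within a range from 3% to 35%.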

Compound 4, a percentage reported as inhibition, in the whole organism at one dose (the size of the read-out at that dose, not a potency): 20%
For compound 4 the middle estimate is 5 percentage points below the measured one; low and high end bracket the measured number.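

In this assay, within the data shown here, hydrogen in place of ethyl on an amide-type nitrogen gives a number 1 percentage points higher from compound 3 to compound 4 (within the scatter), the first step that can be read at this position. The ethylcarbamoyl and carbamoyl forms therefore cannot be told apart on this read-out, at this one dose and time, so the ethyl group is not needed to keep the read-out at the level of compound 3. No supporting measurement bears on this result, and the step stays a bare observation.

As far as these compounds go, whether a longer chain such as butyl on this nitrogen, or a carboxylic acid in place of the carboxamide, would give a step beyond the scatter remains open. The same holds for a basic amine carried on the chain, and a single step at one dose says nothing about how the read-out would respond at other doses or times.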